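Removing the Ethoxy Group from a Shorter Hydroxamate Chain

A few compounds are considered here, and "the series" means these few. Any claim that something is new, unique, unknown or untested is made for them only; others in the source may bear on it.

The measured compounds and their values in a functional assay on PC-3 cells (Homo sapiens) for cytotoxicity; a lower number here means a stronger inhibitor, a higher number a weaker inhibitor:
compound 1 `O=C(CCCCCCC(=O)Nc1nc2ccccc2s1)NO`, 5.44 ug/mL;
compound 2 `CCOc1ccc2nc(NC(=O)CCCCC(=O)NO)sc2c1`, 6.69 ug/mL;
compound 3 `CCOc1ccc2nc(NC(=O)CCCCCCC(=O)NO)sc2c1`, 16.9 ug/mL.

Compound 3 and compound 2 share their core and differ only in the chain that carries the hydroxamate: hydroxycarbamoyl in place of 2-(hydroxycarbamoyl)ethyl on a saturated chain carbon, four bonds along the chain from a carbonyl carbon. Shortening the chain gave a 2.5-fold higher number from compound 2 to compound 3 (0.40 log units; beyond the scatter). Compound 3 and compound 1 differ in one place on the ring: hydrogen in place of ethoxy on an aromatic carbon. That change gave a 3.1-fold lower number from compound 3 to compound 1 (0.49 log units; beyond the scatter). Compound 1 and compound 2 are within the usual scatter of one another, so nothing is said about their order.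

Compound 4 `O=C(CCCCC(=O)Nc1nc2ccccc2s1)NO` has not yet been measured in this assay. Its difference from compound 2 is hydrogen in place of ethoxy on an aromatic carbon, the same change as from compound 3 to compound 1, made on the shorter chain of compound 2. Going by the values given here, the step is expected to be of a similar size, roughly a 2.2-fold lower number from compound 2 to compound 4 (0.35 log units; beyond the scatter), because the one earlier instance is a 3.1-fold lower number from compound 3 to compound 1 (0.49 log units; beyond the scatter), although that instance sits on a different chain length and a single example gives only a weak guide. Compound 4 is therefore estimated at 3 ug/mL, with a likely range from 1.4 ug/mL to 7 ug/mL.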

Compound 4, half-maximal inhibitory concentration: 12.5 ug/mL
Compound 4: the middle estimate sits 4.2-fold (0.62 log units) below what was measured, and the stated range ends below it.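

In this assay, hydrogen in place of ethoxy on an aromatic carbon gives a 1.9-fold higher number from compound 2 to compound 4 (0.27 log units; within the scatter), so the step seen with the longer chain did not carry over to the shorter chain: the same change on two cores in this assay, a 3.1-fold lower number (0.49 log units; beyond the scatter) from compound 3 to compound 1 and a 1.9-fold higher number (0.27 log units; within the scatter) from compound 2 to compound 4, 5.8-fold (0.76 log units) apart, beyond the scatter of two such steps. The chain change did not carry over from one core to the other either, with the core lacking ethoxy giving a 2.3-fold higher number from compound 1 to compound 4 (0.36 log units; beyond the scatter): the same change on two cores in this assay, a 2.5-fold higher number (0.40 log units; beyond the scatter) from compound 2 to compound 3 and a 2.3-fold lower number (0.36 log units; beyond the scatter) from compound 4 to compound 1, 5.8-fold (0.76 log units) apart, beyond the scatter of two such steps. Within these four compounds, the effect of each change therefore depends on the other, but the data do not show why, and with only one pair for each comparison they cannot predict either step on another core.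

The compounds shown leave open whether methoxy or chlorine on the same aromatic carbon would behave like ethoxy, and whether any such group would follow the result from the longer chain or the shorter one. They also leave open how a still longer chain, or one of intermediate length, would fit with these two chain lengths.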